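Pyridinone side chain removed: outlook for compound 4

The source may hold more compounds than are shown below. What is called first, only, known or untested is meant among the compounds shown, and "the series" means these compounds.

Compound 2 `CCCCc1ccc(CNC(=O)Nc2ccccc2)c(=O)n1Cc1ccc(-c2ccccc2-c2nn[nH]n2)cc1` gives 30 nM in a functional assay (aorta) for antagonist activity, with Oryctolagus cuniculus as the target (a higher number here means a weaker inhibitor, a lower number a stronger inhibitor), the highest of the three numbers measured. Compound 1 `CCCCc1ccc(CNCc2ccccc2)c(=O)n1Cc1ccc(-c2ccccc2-c2nn[nH]n2)cc1` gives 1 nM in this assay, and compound 3 `CCCCc1ccc(CN(C(C)C)S(C)(=O)=O)c(=O)n1Cc1ccc(-c2ccccc2-c2nn[nH]n2)cc1` gives 0.9 nM there. The two steps from compound 2 are large: a 30-fold higher number from compound 1 to compound 2 (1.48 log units; beyond the scatter) and a 33-fold lower number from compound 2 to compound 3 (1.52 log units; beyond the scatter), while a 1.1-fold lower number from compound 1 to compound 3 (0.05 log units; within the scatter).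

Compound 4 `CCCCc1cccc(=O)n1Cc1ccc(-c2ccccc2-c2nn[nH]n2)cc1` is the analogue with the side chain taken off altogether: hydrogen in place of ((phenylcarbamoyl)amino)methyl on an aromatic carbon. Within the data shown here, no measured step removes this group, so the direction is not fixed by the data. Among the measured compounds shown here, what the measured steps show is that the identity of the group at this position moves the number widely, and that the group of compound 2 is the one giving the highest number among the three. A deletion is expected to land somewhere between the extremes rather than reproducing the low numbers of compound 1 and compound 3, with considerable uncertainty.

The expected step is a 2.0-fold lower number from compound 2 to compound 4 (0.30 log units; within the scatter). For compound 4 the estimate in this assay is 15 nM, with a range from 2 nM to 120 nM.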

Compound 4, half-maximal inhibitory concentration: 4 nM
Compound 4: the middle estimate sits 3.8-fold (0.57 log units) above what was measured; the range from low to high includes it.
By their numbers in this assay, from the lowest: compounds 3 and 1 (each within the scatter of the next); then compound 4; then compound 2.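

With hydrogen at this position there is now a baseline for the side chains, and in this assay they fall on both sides of it. Removing ((phenylcarbamoyl)amino)methyl gives a 7.5-fold lower number from compound 2 to compound 4 (0.88 log units; beyond the scatter), whereas removing the other two side chains gives a 4.4-fold higher number from compound 3 to compound 4 (0.65 log units; beyond the scatter) and a 4.0-fold higher number from compound 1 to compound 4 (0.60 log units; beyond the scatter), so a side chain here can either raise or lower the number relative to hydrogen, with compound 2 going against any claim that a side chain lowers it. No supporting measurement on hand bears on the reason for these shifts.

Going by these compounds, it remains open whether a plain methyl or aminomethyl group at this position would sit with compound 4 or with compounds 1 and 3. Also open, on these data alone, is whether a methylcarbamoyl group on the amine nitrogen would give a number as high as that of compound 2.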